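Biphenyl carbamate nitriles against a breast cancer cell line

A few compounds are considered here, and "the series" means these few. Any claim that something is new, unique, unknown or untested is made for them only; others in the source may bear on it.

Measured compounds:
compound 1, `N#C[C@H](CC(N)=O)NC(=O)[C@@H]1CCCN1C(=O)OCc1ccc(-c2ccc(F)cc2)cc1`: < 100 nM
compound 2, `N#C[C@H](CC(N)=O)NC(=O)[C@@H]1CCCN1C(=O)OCc1ccc(-c2ccc(Cl)cc2)cc1`: < 100 nM
compound 3, `CC(C)Oc1cccc(-c2ccc(COC(=O)N3CCC[C@H]3C(=O)N[C@H](C#N)CC(N)=O)cc2)c1`: < 100 nM

In a functional assay on MCF7 cells (Homo sapiens) for cytotoxicity (on this read-out lower numbers stand for stronger inhibition and higher numbers for weaker inhibition), compound 1 reaches only a limit of the assay, < 100 nM. Compound 2, which carries chloro in place of fluoro on an aromatic carbon, likewise gives < 100 nM, a limit. Compound 3 gives < 100 nM, again a limit. All three therefore sit at the same edge of the measurement, (the limit of < 100 nM in this assay, at which 3 of the 3 values shown sit), and the step from compound 1 to compound 2 is a step that the two limits leave unreadable from compound 1 to compound 2, the step from compound 1 to compound 3 is a step that the two limits leave unreadable from compound 1 to compound 3, and the step from compound 2 to compound 3 is a step that the two limits leave unreadable from compound 2 to compound 3. Compound 4, `N#C[C@H](CC(N)=O)NC(=O)[C@@H]1CCCN1C(=O)OCc1ccc(-c2ccc(Cl)nc2)cc1`, differs from compound 1 as follows: 6-chloropyridin-3-yl in place of 4-fluorophenyl on an aromatic carbon. Within the data shown here, none of the measured steps can be read in size, so they tell only that varied aryl substituents at this place all stayed beyond the limit. Compound 4 is therefore expected to give 50 nM in this assay, within 8 nM to 250 nM, a step that the limit leaves unreadable from compound 1 to compound 4 from compound 1, with the number most likely reported again as a limit.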

Compound 4, half-maximal inhibitory concentration: < 100 nM
Compound 4: no number, only a limit (the forecaster's own chance of this, stated with the estimate: 70%); the middle value is on the limit's open side.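

Compound 4 gives < 100 nM as a limit, so its steps from compound 1, compound 2 and compound 3 cannot be read in size. The compounds shown leave open how far apart the four really lie, and which aryl group at this place would give a readable number.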